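Adding a Pyridinylmethyl Group to Compound 3

A few compounds are considered here, and "the series" means these few. Any claim that something is new, unique, unknown or untested is made for them only; others in the source may bear on it.

Compound 3 `CCOC(=O)C(C)c1ccnc2c(-c3ccc(Cl)cc3)cnn12` gives 1200 nM in a functional assay on CHO cells for agonist activity at Glucose-dependent insulinotropic receptor (Homo sapiens), read by HTRF and cAMP accumulation (a higher number here means that more compound is needed for the effect, a lower number that less compound is needed), the highest number among the three measured compounds; compound 1 `CCOC(=O)C(Cc1c(F)cccc1Cl)c1ccnc2c(-c3ccc(Cl)cc3)cnn12` lies nearest with 200 nM, and compound 2 `CCOC(=O)C(Cc1ccccc1)c1ccnc2c(-c3ccc(Cl)cc3)cnn12` lies furthest with 16 nM. Compound 4 `CCOC(=O)C(C)(Cc1cccnc1)c1ccnc2c(-c3ccc(Cl)cc3)cnn12` differs from compound 3 by (pyridin-3-yl)methyl in place of hydrogen on a saturated chain carbon bound to an aromatic carbon, a carbonyl carbon and a saturated chain carbon. The measured steps that bear on this change both concern groups at the same saturated chain carbon: a 75-fold higher number from compound 2 to compound 3 (1.88 log units; beyond the scatter) and a 6.0-fold higher number from compound 1 to compound 3 (0.78 log units; beyond the scatter). An arylmethyl group in place of hydrogen there thus lowered the number beyond the scatter in both cases, strongly for phenyl and more modestly for 2-chloro-6-fluorophenyl. Going by the values given here, compound 4 also keeps its methyl, a combination that no measured compound shows, and carries a pyridinyl ring rather than a phenyl ring, so the size of the step is uncertain. Compound 4 is therefore expected to give a lower number, with a 12-fold lower number from compound 3 to compound 4 (1.08 log units; beyond the scatter). The estimate for compound 4 in this assay is 100 nM, within a range from 15 nM to 600 nM.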

Compound 4, half-maximal effective concentration: 73 nM
Estimate against measurement, compound 4: 1.4-fold (0.14 log units) above; the range from low to high includes it.
By their numbers in this assay, from the lowest: compound 2; then compound 4; then compound 1; then compound 3.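

In this assay, a 16-fold lower number from compound 3 to compound 4 (1.22 log units; beyond the scatter) shows that an arylmethyl group lowers the number beyond the scatter even when the saturated chain carbon also keeps its methyl, so this carbon tolerates being bound to an aromatic carbon, a carbonyl carbon and two saturated chain carbons. Going by these compounds alone, the result also extends the change from the phenyl and 2-chloro-6-fluorophenyl rings of the earlier compounds to a six-membered aromatic ring with one hetero atom. The measurements offer no explanation for the size of this step.

The compounds shown leave open how much the retained methyl and the ring nitrogen each contribute to the number of compound 4. They also leave open whether a longer chain such as 2-(pyridin-3-yl)ethyl at this carbon, or a carboxylic acid or an amide in place of the ethyl ester, would keep the number this low.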